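A few compounds are considered here, and "the series" means these few. Any claim that something is new, unique, unknown or untested is made for them only; others in the source may bear on it.

Series notes, cytotoxicity on the shared core.

Compound 1 is `CC(C)(C)C(=O)N(CCCCCCN1C[C@H](O)[C@@H](O)[C@H](O)[C@H]1CO)C1CCCCC1`. In an ADME assay on MDBK cells (Bos taurus) for cytotoxicity, read by MTT assay (a higher number here means that more compound is tolerated, a lower number that less compound is tolerated), compound 1 gives > 500000 nM, which is a limit of the assay and not a number. Compound 2 is `CC(C)(C)S(=O)(=O)N(CCCCCCN1C[C@H](O)[C@@H](O)[C@H](O)[C@H]1CO)C1CCCCC1`, differing from compound 1 only in that a (tert-butyl)sulfonyl stands in place of the (tert-butyl)carbonyl on the amine nitrogen. In this assay compound 2 gives > 500000 nM, again a limit rather than a number. The step that the two limits leave unreadable from compound 1 to compound 2 therefore cannot be read in size or direction. What the two values show is summed up by the limit of > 500000 nM in this assay, at which 2 of the 2 values shown sit.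

Compound 3 is `NC(=O)N(CCCCCCN1C[C@H](O)[C@@H](O)[C@H](O)[C@H]1CO)C1CCCCC1`. The change from compound 2 is carbamoyl in place of (tert-butyl)sulfonyl on an amine nitrogen. Within the data shown here, no measured step covers this exchange; the only step at hand, between compound 1 and compound 2, is unreadable from the two limits. With both measured values sitting at the limit, no step beyond the scatter is expected in this assay, and the most likely outcome for compound 3 is another limit. Compound 3 is expected at 600000 nM, with a range from 250000 nM to 2000000 nM. The expected step is a step that the limit leaves unreadable from compound 2 to compound 3.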

Compound 3, half-maximal cytotoxic concentration: > 500000 nM
Compound 3 ended at the assay's limit; the forecaster's own chance of this, stated with the estimate: 85%; the middle value does not contradict the limit.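

Compound 3 joins compound 1 and compound 2 at a limit in this assay, so no step among these three compounds can be read in size or direction: the limit of > 500000 nM in this assay, at which 3 of the 3 values shown sit.

The compounds shown leave open where the half-maximal cytotoxic concentration of each actually lies, and whether any exchange on the amine nitrogen alters it.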